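The source may report more compounds than this note shows. Statements on the series, on what has been measured and on what is new or still open speak of the compounds shown alone.

Measured compounds in an ADME assay on MT4 cells (Homo sapiens) for cytotoxicity, read by MTT assay, with a stated time of 4 days; on this read-out lower numbers stand for higher toxicity in this test and higher numbers for lower toxicity in this test:
Compound 1 `CCOC(=O)c1cnc(N2CCN(Cc3ccc(C#N)cc3)CC2)nc1Oc1c(C)cc(-c2ccc(C#N)cc2)cc1C` stands at the assay limit of > 125000 nM, not a number.
Compound 2 `CCOC(=O)c1cnc(N2CCN(Cc3cccc(C#N)c3)CC2)nc1Oc1c(C)cc(-c2ccc(C#N)cc2)cc1C` also stands at the limit of > 125000 nM.
Compound 3 `CCOC(=O)c1cnc(N2CCN(Cc3ccc(C(N)=O)cc3)CC2)nc1Oc1c(C)cc(-c2ccc(C#N)cc2)cc1C` gives 66500 nM, the only number shown.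

Among the compounds with values here, compound 3 thus holds the one readable value; the other two sit at the limit (the limit of > 125000 nM in this assay, at which 2 of the 3 values shown sit). Compound 4 `CCOC(=O)c1cnc(N2CCN(Cc3cc(C)cc(C)c3)CC2)nc1Oc1c(C)cc(-c2ccc(C#N)cc2)cc1C` differs from compound 3 in that (3,5-dimethylphenyl in place of 4-carbamoylphenyl on a saturated chain carbon bound to an amine nitrogen in a ring). Within the data shown here, no measured step carries a 3,5-dimethylphenyl. Among the measured compounds shown here, the steps of an at least 1.8-fold lower number from compound 1 to compound 3 (0.27 log units; that floor lies within the scatter) and an at least 1.8-fold lower number from compound 2 to compound 3 (0.27 log units; that floor lies within the scatter) both run from a limit to the one number, so their floors lie within the scatter and fix no direction for a change away from carbamoyl. The step that the two limits leave unreadable from compound 1 to compound 2 adds nothing readable. The expected step of a 1.5-fold higher number from compound 3 to compound 4 (0.18 log units; within the scatter) is small, with a fair chance of a limit again. Compound 4 is estimated at 100000 nM, between 40000 nM and 250000 nM.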

Compound 4, half-maximal cytotoxic concentration: > 125000 nM
Compound 4: a limit, no number; the forecaster's own chance of this, stated with the estimate: 45%; middle value at least 1.2-fold (0.09 log units) away from the limit.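

In this assay, the change to 3,5-dimethylphenyl on this saturated chain carbon gives an at least 1.8-fold higher number from compound 3 to compound 4 (0.27 log units; that floor lies within the scatter). Compound 4 gives a limit, not a number, so a substituent without hydrogen-bond donors or acceptors now sits there alongside 4-cyanophenyl and 3-cyanophenyl: the limit of > 125000 nM in this assay, at which 3 of the 4 values shown sit. The steps from compound 1 and compound 2 to compound 4 cannot be read.

Still open, from the compounds shown here alone, is how far compound 1, compound 2 and compound 4 lie past the limit. Also open, going by these compounds, is whether a carboxylic acid or an amine on this aromatic ring would give a number, as carbamoyl does in compound 3.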